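A few compounds are considered here, and "the series" means these few. Any claim that something is new, unique, unknown or untested is made for them only; others in the source may bear on it.

Measured in an ADME assay for pharmacokinetics, read by LC-MS, in phosphate buffer, with a stated time of 120 min, at pH 7.4, tested at 1 uM, in the presence of a further agent that is not named here; on this read-out higher numbers stand for a longer-lived compound and lower numbers for a shorter-lived compound:
Compound 1 `C=C(CO)C(=O)Nc1ccccc1` gives > 8.53 h, a limit of the assay.
Compound 2 `C=C(Cl)C(=O)Nc1ccccc1` gives 0.05 h.
Compound 3 `C/C=C/C(=O)Nc1ccccc1` gives > 8.53 h, a limit of the assay.

Compound 3 thus stands at the upper limit, where compound 1 also sits (the limit of > 8.53 h in this assay, at which 2 of the 3 values shown sit). Only compound 2 returns a number, and the step of an at least 170-fold higher number from compound 2 to compound 3 (2.23 log units; beyond the scatter) is large. Compound 4 `CCN(CC)C/C=C/C(=O)Nc1ccccc1` differs from compound 3 by diethylamino in place of hydrogen on a saturated chain carbon bound to a double-bonded chain carbon. Among the measured compounds shown here, no measured step touches this saturated chain carbon; the measured steps alter the double-bonded chain carbon, as in an at least 170-fold lower number from compound 1 to compound 2 (2.23 log units; beyond the scatter), while a step that the two limits leave unreadable from compound 1 to compound 3 cannot be read between two limits. The change has no direct precedent among these three compounds. Compound 4 is expected to give 4 h, within 1 h to 8.53 h. That estimate means an expected step of an at least 2.1-fold lower number from compound 3 to compound 4 (0.32 log units; beyond the scatter).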

Compound 4, half-life: 2.83 h
Compound 4: the middle estimate sits 1.4-fold (0.15 log units) above what was measured; the range from low to high includes it.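

Among the compounds shown here, this is the first reading of a change on the saturated chain carbon bound to a double-bonded chain carbon: diethylamino in place of hydrogen gives an at least 3.0-fold lower number from compound 3 to compound 4 (0.47 log units; beyond the scatter). Substitution at this carbon therefore registers in this assay, and compound 4 returns a number. The full size of the step stays unresolved, as the value of compound 3 is a limit: the limit of > 8.53 h in this assay, at which 2 of the 4 values shown sit.

From the compounds shown here alone, whether the step is specific to diethylamino or extends to other groups at this carbon remains open. Dimethylamino, a smaller amine, or a carboxylic acid in the same place would test this.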